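The source may report more compounds than this note shows. Statements on the series, on what has been measured and on what is new or still open speak of the compounds shown alone.

Compound 1 `COc1ccc(CNC(=O)c2cccc(C(C)Oc3ccnc(Nc4cnn(C)c4)c3)c2)cc1OC` gives 38500 nM in a functional assay on NCI-H3122 cells (Homo sapiens) for antiproliferative activity, read by MTT assay, with a stated time of 48 h; a higher number here means a weaker inhibitor, a lower number a stronger inhibitor.
Compound 2 `COc1ccc(CNC(=O)c2cccc(C(C)Oc3ccnc(Nc4cnn(C5CCN(C)CC5)c4)c3)c2)cc1OC` gives 14800 nM in this assay.

Among the compounds with values here, of these two measured compounds, compound 2 holds the lower number in this assay; the only neighbour is compound 1, and the step of a 2.6-fold lower number from compound 1 to compound 2 (0.42 log units; beyond the scatter) is beyond the scatter. Compound 3 `COc1ccc(CNC(=O)c2cccc(C(C)Oc3ccnc(Nc4ncccn4)c3)c2)cc1OC` has not yet been measured. It differs from compound 2 by the change (pyrimidin-2-yl in place of 1-(1-methylpiperidin-4-yl)-1H-pyrazol-4-yl on a nitrogen on an aromatic ring). Within the data shown here, the single measured step, a 2.6-fold lower number from compound 1 to compound 2 (0.42 log units; beyond the scatter), concerns the group on the aromatic nitrogen of the pyrazole and is modest in size; it bears only loosely on the present change, which removes that whole pyrazole ring together with its 1-methylpiperidin-4-yl group and puts a pyrimidin-2-yl in its place. Among the measured compounds shown here, no measured step covers a swap of this kind, so the direction rests on weak ground. Since compound 2 owes its lower number to the 1-methylpiperidin-4-yl group, as a 2.6-fold lower number from compound 1 to compound 2 (0.42 log units; beyond the scatter) shows, and compound 3 lacks that group, compound 3 is expected to give a higher number, estimated at 40000 nM with a range of 12000 nM to 130000 nM. That estimate means a step of a 2.7-fold higher number from compound 2 to compound 3 (0.43 log units; beyond the scatter), expected to lie beyond the scatter.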

Compound 3, half-maximal inhibitory concentration: > 100000 nM
Compound 3: a limit, no number; the forecaster's own chance of this, stated with the estimate: 20%; middle value at least 2.5-fold (0.39 log units) from the limit.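

Compound 3 stands at a limit of this assay and not at a number: the limit of > 100000 nM in this assay, at which 1 of the 3 values shown sits. Exchanging the 1-(1-methylpiperidin-4-yl)-1H-pyrazol-4-yl on the nitrogen for pyrimidin-2-yl gives an at least 6.7-fold higher number from compound 2 to compound 3 (0.82 log units; beyond the scatter), and exchanging the 1-methyl-1H-pyrazol-4-yl for the same pyrimidin-2-yl gives an at least 2.5-fold higher number from compound 1 to compound 3 (0.41 log units; beyond the scatter). The earlier step, a 2.6-fold lower number from compound 1 to compound 2 (0.42 log units; beyond the scatter), had varied only the group on the pyrazole, whereas these two steps show that replacing the pyrazole itself with pyrimidin-2-yl moves the number upward from both pyrazole compounds, to a limit rather than to a readable value.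

The compounds shown leave open whether this rise belongs to the pyrimidin-2-yl ring in particular or would follow any replacement of the pyrazole, such as a simple phenyl or pyridine ring on the same nitrogen. They also leave open whether an amine such as the 1-methylpiperidin-4-yl group, carried on the pyrimidin-2-yl ring instead of the pyrazole, would bring the number back below the limit.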